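A few compounds are considered here, and "the series" means these few. Any claim that something is new, unique, unknown or untested is made for them only; others in the source may bear on it.

Measured compounds:
compound 1, `O=C(O)COCCCC[C@H]1[C@H](F)CC[C@@H]1NS(=O)(=O)c1ccc(F)cc1F`, 1800 nM in a functional assay on a cell-free system (plasma) for inhibition of thromboxane A2 receptor (Homo sapiens), read by turbidimetry; a higher number here means a weaker inhibitor, a lower number a stronger inhibitor
compound 2, `O=C(O)COCCCC[C@H]1[C@H](F)CC[C@@H]1NS(=O)(=O)c1ccc(F)cc1`, 1800 nM
compound 3, `O=C(O)COCCCC[C@H]1[C@H](F)CC[C@@H]1NS(=O)(=O)c1ccccc1`, 1700 nM

Compound 1 stands level with compound 2 at the digits shown, the two together giving the highest numbers of the three; the gap to compound 3 is a 1.1-fold lower number from compound 1 to compound 3 (0.02 log units; within the scatter). The three measured steps, no change at the digits printed from compound 1 to compound 2 (within the scatter), a 1.1-fold lower number from compound 1 to compound 3 (0.02 log units; within the scatter) and a 1.1-fold lower number from compound 2 to compound 3 (0.02 log units; within the scatter), all change only the aryl group on the sulfonyl sulfur and all stay within the scatter.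

Compound 4, `O=C(O)CC/C=C/C[C@H]1[C@H](F)CC[C@@H]1NS(=O)(=O)c1ccc(F)cc1F`, differs from compound 1 in another part of the molecule: 4-carboxybut-1-en-1-yl in place of 3-(carboxymethoxy)propyl on a saturated chain carbon bound to a saturated ring carbon. Going by the values given here, no measured step touches this chain, so the measured steps give no direct guidance on its size or direction. With the aryl changes leaving this assay unmoved and nothing known about the chain, the step is expected to be a 1.2-fold lower number from compound 1 to compound 4 (0.08 log units; within the scatter), with a wide margin on both sides. Compound 4 is therefore estimated at 1500 nM, in the range from 400 nM to 6000 nM.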

Compound 4, half-maximal inhibitory concentration: 1600 nM
Compound 4: middle estimate off by 1.1-fold (0.03 log units), on the low side, and the stated range covers the measured number.
By their numbers in this assay, from the lowest: compounds 4, 3, 1 and 2 (each within the scatter of the next).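

Going by these compounds alone, the chain on a saturated chain carbon bound to a saturated ring carbon, which no earlier step touched, can now be read in this assay: placing 4-carboxybut-1-en-1-yl where 3-(carboxymethoxy)propyl stood gives a 1.1-fold lower number from compound 1 to compound 4 (0.05 log units; within the scatter) on an otherwise unchanged molecule. This one exchange thus shows that, like the aryl group on the sulfonyl sulfur, this chain can change from the ether-containing form to the unsaturated form without moving the number beyond the scatter. Nothing available explains this result.

The compounds shown leave open whether a longer chain, or an amide or tetrazole in place of the carboxylic acid, would leave the number equally unmoved. They also leave open what hydrogen or hydroxyl would do in place of the fluoro on the saturated ring carbon.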